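Swapping the Ether Group: From Cyclohexyl to Tert-Butyl

The source may report more compounds than this note shows. Statements on the series, on what has been measured and on what is new or still open speak of the compounds shown alone.

Of the compounds shown here, three built on one shared core have been measured in a functional assay for inhibition of sodium/hydrogen exchanger (Oryctolagus cuniculus); a higher number here means a weaker inhibitor, a lower number a stronger inhibitor. Compound 1, `Cc1cc(Sc2ccncc2)c(S(C)(=O)=O)cc1C(=O)N=C(N)N`, gives 13 nM. Compound 2, `CCOc1cc(C)c(C(=O)N=C(N)N)cc1S(C)(=O)=O`, gives 19 nM, and the move between them is a 1.5-fold higher number from compound 1 to compound 2 (0.16 log units; within the scatter). Compound 3, `Cc1cc(OC2CCCCC2)c(S(C)(=O)=O)cc1C(=O)N=C(N)N`, gives 37 nM, the highest of the three numbers. The step of a 2.8-fold higher number from compound 1 to compound 3 (0.45 log units; beyond the scatter) sets compound 3 apart from compound 1, whereas the step of a 1.9-fold higher number from compound 2 to compound 3 (0.29 log units; within the scatter) does not set it apart from compound 2.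

Compound 4, `Cc1cc(OC(C)(C)C)c(S(C)(=O)=O)cc1C(=O)N=C(N)N`, differs from compound 3 in one place: tert-butyl in place of cyclohexyl on an oxygen on an aromatic ring. The measured step that bears most directly on this is a 1.9-fold higher number from compound 2 to compound 3 (0.29 log units; within the scatter), in which only the group on the same oxygen was exchanged and the number stayed within the scatter. The step of a 2.8-fold higher number from compound 1 to compound 3 (0.45 log units; beyond the scatter) replaced the whole group attached to the aromatic carbon and is a looser guide. Because a 1.9-fold higher number from compound 2 to compound 3 (0.29 log units; within the scatter) stayed within the scatter, exchanging the group on the oxygen once more is expected to leave the number close to that of compound 3, with no step beyond the scatter in either direction. The expected step is a 1.2-fold lower number from compound 3 to compound 4 (0.09 log units; within the scatter). Compound 4 is therefore estimated at 30 nM in this assay, with a range from 12 nM to 75 nM.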

Compound 4, half-maximal inhibitory concentration: 9.4 nM
Compound 4: the middle estimate sits 3.2-fold (0.50 log units) above what was measured; the measured number lies below the stated range.
By their numbers in this assay, from the lowest: compounds 4, 1, 2 and 3 (each within the scatter of the next, the first and the last beyond it).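

The group on this oxygen matters more than ethyl and cyclohexyl alone suggested. In this assay, tert-butyl in place of cyclohexyl gives a clear change (in numbers, a 3.9-fold lower number from compound 3 to compound 4 (0.60 log units; beyond the scatter)) and tert-butyl in place of ethyl also gives one (a 2.0-fold lower number from compound 2 to compound 4 (0.31 log units; beyond the scatter)), so tert-butoxy can be told apart from both of the other ethers, although those two could not be told apart from each other. The much larger exchange at the same aromatic carbon behaves differently (a 1.4-fold lower number from compound 1 to compound 4 (0.14 log units; within the scatter)), which shows that a simple tert-butoxy group can stand in for the (pyridin-4-yl)sulfanyl group of compound 1 without a change that exceeds the scatter. No measured evidence here accounts for any of these differences.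

The compounds shown leave open whether this result is particular to tert-butyl or extends to other branched groups on the oxygen, such as isopropyl or cyclopentyl. They also leave open how this assay would respond to an amine on the same aromatic carbon, such as piperidine, in place of the ether oxygen.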